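Phenyl count and receptor binding in the series

A few compounds are considered here, and "the series" means these few. Any claim that something is new, unique, unknown or untested is made for them only; others in the source may bear on it.

Measured compounds:
- compound 1 `O=C(O)CCCCCCCCn1nc(-c2ccccc2)c(-c2ccccc2)c1-c1ccccc1`: in an assay on isolated protein for displacement of a labelled ligand from prostacyclin receptor (Homo sapiens) (a higher number here means a weaker inhibitor, a lower number a stronger inhibitor), compound 1 gives 160 nM
- compound 2 `O=C(O)CCCCCCCCn1nc(-c2ccccc2)cc1-c1ccccc1`: for compound 2 this assay reports only a limit, > 10000 nM
- compound 3 `O=C(O)CCCCCCCCn1cc(-c2ccccc2)cn1`: for compound 3 this assay reports only a limit, > 10000 nM

Compound 3 thus stands at the limit of > 10000 nM in this assay, at which 2 of the 3 values shown sit, with no number to place it among the others. Within the data shown here, the one measured step, an at least 62-fold higher number from compound 1 to compound 2 (1.79 log units; beyond the scatter), is large and runs toward weaker binding when a phenyl is removed. Compound 4 `O=C(O)CCCCCCCCn1cc(-c2ccccc2)c(-c2ccccc2)n1` differs from compound 3 by phenyl in place of hydrogen on an aromatic carbon, the opposite direction of that step, so a gain is expected; yet compound 2, also carrying two phenyls, sits at the limit, so the gain may stay below a measurable number. Compound 4 is expected at 8000 nM, range 1500 nM to 30000 nM. The expected step is an at least 1.2-fold lower number from compound 3 to compound 4 (0.09 log units; that floor lies within the scatter).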

Compound 4, half-maximal inhibitory concentration: 350 nM
Compound 4: middle estimate off by 23-fold (1.36 log units), on the high side; the whole stated range lies above it.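

Added on the aromatic carbon next to the ring nitrogen and next to the ring atom that bears a phenyl group, phenyl brings binding from a limit to a measurable number, with a large gain: an at least 28-fold lower number from compound 3 to compound 4 (1.45 log units; beyond the scatter). Starting from compound 1, losing a phenyl costs much less in this step, a 2.2-fold higher number from compound 1 to compound 4 (0.34 log units; beyond the scatter), than in the other listed loss, an at least 62-fold higher number from compound 1 to compound 2 (1.79 log units; beyond the scatter). The cost of losing a phenyl therefore depends on which carbon loses it. Open, going by these compounds, is whether a methyl or a chlorine on this carbon would keep the gain, and whether a shorter acid chain would keep it.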